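Methylsulfanyl to selenium analogue on the bis-acyl isothiourea core

A few compounds are considered here, and "the series" means these few. Any claim that something is new, unique, unknown or untested is made for them only; others in the source may bear on it.

Compound 1 `CS/C(=N\C(=O)c1ccno1)NC(=O)c1ccno1` is one of two members of this series measured in an ADME assay on MCF-10A cells (Homo sapiens) for cytotoxicity, read by MTT assay, with a stated time of 72 h; a higher number here means a weaker inhibitor of growth, a lower number a stronger inhibitor of growth. For compound 1 the readout is a limit rather than a number, > 100000 nM. Compound 2 `CS/C(=N\C(=O)c1cnc2ccccc2c1)NC(=O)c1cnc2ccccc2c1` is the other measured member; in this assay compound 2 gives 42200 nM. Within the data shown here, no single-point step between measured compounds exists, and the only evidence on compound 1 is the limit of > 100000 nM in this assay, at which 1 of the 2 values shown sits.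

Compound 3 `C[Se]/C(=N\C(=O)c1ccno1)NC(=O)c1ccno1` is not yet measured. It differs from compound 1 by a group of 2 heavy atoms (1 carbon, 1 selenium; no ring) in place of a group of 2 heavy atoms (1 carbon, 1 sulfur; no ring), on a carbon with a double bond to nitrogen. With compound 1 sitting at the limit, the step to compound 3 cannot be computed from data; the expected step in this assay is none beyond the scatter, most likely another limit, as a number no higher from compound 1 to compound 3 (the limit leaves the size open). Compound 3 is therefore estimated at 100000 nM, with a range from 30000 nM to 300000 nM.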

Compound 3, concentration for total growth inhibition: 15400 nM
Beside the measured number, compound 3's estimate is 6.5-fold (0.81 log units) above it, outside the stated range (below it).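

In this assay, among these compounds, replacing methylsulfanyl with the group of carbon and selenium, on a carbon with a double bond to nitrogen, gives the first single-place comparison: an at least 6.4-fold lower number from compound 1 to compound 3 (0.81 log units; beyond the scatter). This position therefore affects the read-out, since this one change, with the rest of the core of compound 1 unchanged, turns a limit into a measured number. The step has only a lower bound, and its full size stays open, as the reading for compound 1 is a limit and not a number: the limit of > 100000 nM in this assay, at which 1 of the 3 values shown sits.

From the compounds shown here alone, whether the same change lowers the number on the core of compound 2 remains open. Also open, going by these compounds, is whether the step is specific to selenium, or whether other groups at this carbon, such as an ethylsulfanyl chain or an amine, would shift the number too.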